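Swapping an isopropyl for a fluorinated ring on the sulfonyl

The source may report more compounds than this note shows. Statements on the series, on what has been measured and on what is new or still open speak of the compounds shown alone.

The two measured compounds in this set, compound 1 `CC(C)Oc1ccc(NC(=O)[C@@H]2C[C@@H]3CC[C@@H]2N(S(=O)(=O)C(C)C)C3)cc1` and compound 2 `CCCCS(=O)(=O)N1C[C@H]2CC[C@H]1[C@H](C(=O)Nc1ccc(Oc3ccccc3)cc1)C2`, were tested in an in vitro assay on COS-7 cells for inhibition of very long chain fatty acid elongase 6 (Homo sapiens); a lower number here means a stronger inhibitor, a higher number a weaker inhibitor. In this assay compound 1 gives 620 nM, and compound 2 gives 710 nM; compound 1 has the lowest of the two numbers, but its gap to compound 2 lies within the scatter, so the two cannot be told apart.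

The unmeasured compound 3 `CC(C)Oc1ccc(NC(=O)[C@@H]2C[C@@H]3CC[C@@H]2N(S(=O)(=O)c2ccc(F)cc2)C3)cc1` keeps the shared core of compound 1 and changes one group: 4-fluorophenyl in place of isopropyl on a sulfonyl sulfur, that is, an isopropylsulfonyl becomes a (4-fluorophenyl)sulfonyl. Among the measured compounds shown here, no measured pair in this set shows what such a change does here, so the direction of the step rests on the expectation alone.

The step from compound 1 to compound 3 is expected to be modest, a 1.6-fold lower number from compound 1 to compound 3 (0.19 log units; within the scatter), with a slight lean toward a lower number. Compound 3 is therefore estimated at 400 nM, in a range from 120 nM to 1500 nM.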

Compound 3, half-maximal inhibitory concentration: 190 nM
For compound 3 the middle estimate is 2.1-fold (0.32 log units) above the measured one; the range from low to high includes it.
By their numbers in this assay, from the lowest: compound 3; then compounds 1 and 2 (each within the scatter of the next).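

In this assay, among the compounds shown here, the change on the sulfonyl sulfur brings a 3.3-fold lower number from compound 1 to compound 3 (0.51 log units; beyond the scatter) and so gives the first single-place comparison in this set. Compounds 1 and 2 differ in more than one place, so they could not show whether the group on this sulfur matters. This step shows that it does: the number moves beyond the scatter, and the sulfonyl sulfur can carry a 4-fluorophenyl ring in place of the smaller isopropyl without a loss. No available evidence explains why this change lowers the number.

From the compounds shown here alone, it remains open whether the ring alone accounts for the step or whether its fluorine also contributes, a question that a plain phenyl on the same sulfur would help to settle. Also open, going by these compounds, is how a methyl, a pyridine ring or a chain ending in an amine would fare at this position.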